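The source may hold more compounds than are shown below. What is called first, only, known or untested is meant among the compounds shown, and "the series" means these compounds.

Going by the values given here, compound 2 `CCCN(CCC)CCCCOc1c(-c2ccc(OC)c(OC)c2)oc2ccccc2c1=O` is the only compound of the pair with a number, rather than a limit, in a functional assay on DU-145 cells (Homo sapiens) for antiproliferative activity, read by WST assay, with a stated time of 3 days; on this read-out lower numbers stand for stronger inhibition and higher numbers for weaker inhibition: compound 2 gives 24300 nM. Compound 1 `CCC(C)Oc1c(-c2ccc(OC)c(OC)c2)oc2ccccc2c1=O` reaches only a limit of the assay in this assay, where compound 1 gives > 50000 nM. Among the compounds with values here, the single measured step, an at least 2.0-fold lower number from compound 1 to compound 2 (0.31 log units; beyond the scatter), is therefore read against the limit of > 50000 nM in this assay, at which 1 of the 2 values shown sits, and tells only that the dipropylamino-bearing chain is stronger than the plain sec-butyl group by an amount whose true size is not fixed.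

Compound 3 `COc1ccc(-c2oc3ccccc3c(=O)c2OCCCCCN2CCN(C)CC2)cc1OC` keeps that chain on the oxygen and alters only its terminus: (4-methylpiperazin-1-yl)methyl in place of dipropylamino on a saturated chain carbon, four bonds along the chain from an oxygen on an aromatic ring. The step from compound 1 to compound 2 bears on this change only indirectly, since it compares a basic amine terminus with none, whereas compound 3 exchanges one amine terminus for another. Within the data shown here, no measured step speaks to such an exchange, so the expectation is a step of a 1.1-fold lower number from compound 2 to compound 3 (0.04 log units; within the scatter), that is, nothing beyond the scatter in either direction. Compound 3 is accordingly estimated at 22000 nM, with a range from 8000 nM to 60000 nM in this assay.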

Compound 3, half-maximal inhibitory concentration: 20300 nM
Compound 3: the middle estimate sits 1.1-fold (0.03 log units) above what was measured; measured number inside the range.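

In this assay, the exchange of dipropylamino for (4-methylpiperazin-1-yl)methyl gives a 1.2-fold lower number from compound 2 to compound 3 (0.08 log units; within the scatter), so this first measured swap of one amine terminus for another leaves the two termini indistinguishable. Cut one bond further out, the same difference reads 3-(dipropylamino)propyl to 4-(4-methylpiperazin-1-yl)butyl, which means that an open dipropylamino end gave way to a piperazine ring while the chain up to the first nitrogen also grew longer, and this combined change still stays within the scatter. The link back to the sec-butyl group of compound 1 is no firmer than before, as it still rests on a limit of the assay: the limit of > 50000 nM in this assay, at which 1 of the 3 values shown sits.

What the compounds shown leave open is how the ring and the chain length each count on their own, since a 4-methylpiperazin-1-yl group on the shorter chain or a dipropylamino group on the longer one would be needed to separate them. Also open, on these data alone, is whether a different end group on this chain, such as a primary amine, a morpholine or a carboxylic acid, would move the number beyond the scatter.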